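The source may report more compounds than this note shows. Statements on the series, on what has been measured and on what is new or still open speak of the compounds shown alone.

Measured so far:
Compound 1, `O=C(O)CCc1ccc(OCc2nc(-c3ccccc3Cl)no2)cc1`: in a functional assay on CHO cells for agonist activity at Free fatty acid receptor 1 (Homo sapiens), read by FLIPR and calcium flux, in the presence of a further agent that is not named here (a higher number here means that more compound is needed for the effect, a lower number that less compound is needed), compound 1 gives 1200 nM.
Compound 2, `O=C(O)CCc1ccc(OCc2nc(-c3ccccc3)no2)cc1`: in this assay compound 2 gives 1130 nM.

Compound 2 and compound 1 sit so close together that the step of a 1.1-fold lower number from compound 1 to compound 2 (0.03 log units; within the scatter) falls within the scatter of repeated measurements; on the numbers shown, the two cannot be told apart. Compound 3, `O=C(O)CCc1ccc(OCc2nc(-c3ccc(F)cc3)no2)cc1`, has not yet been measured. It differs from compound 2 in one place: fluoro in place of hydrogen on an aromatic carbon.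

For the measured compounds named here, only one measured step bears on this change. From compound 1 to compound 2 a chloro was replaced by hydrogen on an aromatic carbon of the same ring, and the step of a 1.1-fold lower number from compound 1 to compound 2 (0.03 log units; within the scatter) was within the scatter. A halogen on that ring therefore made no visible difference in this assay, and the fluoro that enters in compound 3 is a smaller halogen at another place on the ring. For compound 3 the expected step of a 1.0-fold lower number from compound 2 to compound 3 (0.01 log units; within the scatter) is none beyond the scatter. Compound 3 is accordingly estimated at 1100 nM, with a range from 550 nM to 2300 nM.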

Compound 3, half-maximal effective concentration: 680 nM
Estimate against measurement, compound 3: 1.6-fold (0.21 log units) above; the measured number falls inside the stated range.
By their numbers in this assay, from the lowest: compounds 3, 2 and 1 (each within the scatter of the next).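

With a fluoro on an aromatic carbon para to a large group, the step of a 1.7-fold lower number from compound 2 to compound 3 (0.22 log units; within the scatter) in this assay stays inside the scatter, so phenyl and 4-fluorophenyl cannot be told apart at this place. The step of a 1.8-fold lower number from compound 1 to compound 3 (0.25 log units; within the scatter) for 4-fluorophenyl in place of 2-chlorophenyl is also inside the scatter, which means that the two halogens, each at its own place on the ring, can be told apart neither from each other nor from the unsubstituted phenyl ring on these numbers. The flat picture now covers two different halogens at two places on this ring, whereas the earlier pair covered only a chloro, and no evidence is available that would explain any of these numbers.

The compounds shown leave open whether any group on this ring can shift the number beyond the scatter, for example a methoxy, a trifluoromethyl or an amine in the place now held by the fluoro. They also leave open whether a chloro in that same place would read like the fluoro, and whether two halogens on one ring would behave as either does alone.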